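This account rests on a few compounds, and the source may have more. Where it says the series, first, only, none or still open, it means among the compounds named here.

In a physicochemical assay for acid dissociation, compound 1 `COC(=O)c1cc(S(N)(=O)=O)ccc1S(=O)(=O)CCCO` gives 8.9 and compound 2 `Nc1cc(S(N)(=O)=O)ccc1S(=O)(=O)CCO` gives 9.5 while compound 3 `CC(=O)OCCS(=O)(=O)c1ccc(S(N)(=O)=O)s1` gives 8.65 as its reading. Compound 3 thus stands within the scatter of compound 1 and lies lower than compound 2 by a gap beyond the scatter.

Still unmeasured is compound 4 `NS(=O)(=O)c1ccc(S(=O)(=O)CCCO)s1` which differs from compound 3 in one place: hydroxymethyl in place of acetoxy on a saturated chain carbon, two bonds along the chain from a sulfonyl sulfur with hydroxymethyl in place of acetoxy on a saturated chain carbon, two bonds along the chain from a sulfonyl sulfur. Cut one bond further out, the same difference reads 2-acetoxyethyl to 3-hydroxypropyl.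

Going by the values given here, no pair of measured compounds shows this change alone, so this assay offers no direct step to lean on. The nearest guide is indirect. Compound 1 carries the 3-hydroxypropyl chain on another core and gives 8.9 within the scatter of compound 3 at 8.65 so the swap of chain is expected to matter little. The expected move a number 0.05 log units higher from compound 3 to compound 4 (within the scatter) is therefore none beyond the scatter. For compound 4 the estimated value is 8.7 with an expected range from 8.4 to 9 as its likely span.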

Compound 4, acid dissociation constant: 8.32
Estimate against measurement, compound 4: 0.38 log units above; measured number below the stated range.
By their numbers in this assay, from the lowest: compound 4; then compounds 3 and 1 (each within the scatter of the next); then compound 2.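

Going by these compounds alone, this is the first direct reading of hydroxymethyl in place of acetoxy on a saturated chain carbon, two bonds along the chain from a sulfonyl sulfur: in this assay the change gives a number 0.33 log units lower from compound 3 to compound 4 (beyond the scatter) on the shared core. The earlier compounds shown here held no pair differing in one place, so only now can it be said that what sits at this end of the chain registers in the read-out, modestly but beyond the scatter. Nothing measured on these compounds accounts for the size or direction of this step.

The change replaces 2-acetoxyethyl with 3-hydroxypropyl, so the compounds shown cannot separate the loss of the acetoxy group from the difference in chain, and a 2-hydroxyethyl chain on the same core would be the pair to read that apart. On these data alone, it also remains open whether the step holds on the core of compound 1 or compound 2, and where a carboxylic acid or a longer chain ending in hydroxyl would fall at this place in this assay on this scale.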